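Trimming the amide aryl: from compound 2 to compound 4

The source may report more compounds than this note shows. Statements on the series, on what has been measured and on what is new or still open speak of the compounds shown alone.

In a functional assay on HCT-116 cells (Homo sapiens) for cytotoxicity, read by MTT assay, with a stated time of 72 h (a lower number here means a stronger inhibitor of growth, a higher number a weaker inhibitor of growth), compound 2 `COc1ccc(CS(=O)(=O)CC(=O)Nc2c(C)cc(C)cc2C)cc1[N+](=O)[O-]` gives 7910 nM. Compound 1 `COc1ccc(CS(=O)(=O)/C=C/c2ccc(OC)c(OC)c2OC)cc1N` gives 5310 nM in this assay, a number within the usual scatter of that of compound 2, so the two stand together. Compound 3 `COc1ccc(CS(=O)(=O)CC(=O)Nc2c(C)cc(C)cc2C)cc1N` reaches only a limit in this assay, > 30000 nM. Among the compounds with values here, the single measured step, an at least 3.7-fold higher number from compound 2 to compound 3 (0.57 log units; beyond the scatter), is itself bounded by the limit of > 30000 nM in this assay, at which 1 of the 3 values shown sits, and concerns the nitro group, not the amide.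

Compound 4 `COc1ccc(CS(=O)(=O)CC(=O)Nc2ccccc2)cc1[N+](=O)[O-]` differs from compound 2 in one place: phenyl in place of 2,4,6-trimethylphenyl on an amide-type nitrogen. Within the data shown here, no measured step touches the amide-type nitrogen, so no step beyond the scatter in this assay can be argued from these data. Compound 4 is therefore expected to give about 8000 nM, within a range of 3000 nM to 25000 nM. That expectation means a step of a 1.0-fold higher number from compound 2 to compound 4 (0.00 log units; within the scatter).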

Compound 4, concentration for 50% growth inhibition: > 30000 nM
Compound 4 ended at the assay's limit (the forecaster's own chance of this, stated with the estimate: 15%); middle value at least 3.7-fold (0.57 log units) from the limit.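

Within the data shown here, replacing 2,4,6-trimethylphenyl with phenyl on the amide-type nitrogen gives an at least 3.7-fold higher number from compound 2 to compound 4 (0.57 log units; beyond the scatter), which shows that this position, untouched by the earlier steps, bears on the result in this assay. Compound 2 now has two single changes, at the nitro group and at the amide aryl, and both end at the limit. The full size of the new step cannot be read, as the result for compound 4 is a limit and not a number: the limit of > 30000 nM in this assay, at which 2 of the 4 values shown sit.

The compounds shown leave open how many of the three methyl groups the result depends on. They also leave open whether a phenyl carrying a single methyl, or a 2,4,6-triethylphenyl or chlorophenyl group, would keep a measurable number.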